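A few compounds are considered here, and "the series" means these few. Any claim that something is new, unique, unknown or untested is made for them only; others in the source may bear on it.

Of the compounds shown here, two from the same series have been tested in an assay on HEK293 cells for inhibition of transient receptor potential cation channel subfamily M member 8 (Homo sapiens), read by FLIPR and calcium flux; on this read-out lower numbers stand for stronger inhibition and higher numbers for weaker inhibition. Compound 1, with the structure `CN(C(=O)c1ccccc1OCc1ccccc1)[C@@H]1CCNC1`, gives a result of > 10000 nM, which is a limit of the assay rather than a number. Compound 2, with the structure `CCN(C(=O)c1ccccc1OCc1ccccc1)C1CCNC1`, gives > 5000 nM, again a limit rather than a number. The step that the two limits leave unreadable from compound 1 to compound 2 cannot be read, since both results are limits, as recorded in the limit of > 10000 nM in this assay, at which 1 of the 2 values shown sits, and (the limit of > 5000 nM in this assay, at which 1 of the 2 values shown sits). Compound 2 therefore stands at a limit, with no measured number alongside it to compare with. The next compound, compound 3 with the structure `NC1CCN(C(=O)c2ccccc2OCc2ccccc2)C1`, differs from compound 2 by a group of 6 heavy atoms (4 carbon, 2 nitrogen; one five-membered non-aromatic ring with 1 hetero atom) in place of a group of 8 heavy atoms (6 carbon, 2 nitrogen; one five-membered non-aromatic ring with 1 hetero atom), on a carbonyl carbon. Among the measured compounds shown here, no measured step bears on this change: the single step available is unreadable, and no number is known for any compound. The expectation for compound 3 is therefore only that it stays weak, with the step that the limit leaves unreadable from compound 2 to compound 3 expected to be small or absent. The estimated value for compound 3 in this assay is 8000 nM, within a range from 2000 nM to 30000 nM, and most likely reported again only as a limit.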

Compound 3, antagonist equilibrium constant: > 10000 nM
Compound 3: no number, only a limit; the forecaster's own chance of this, stated with the estimate: 70%; middle value at least 1.2-fold (0.09 log units) from the limit.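

Compound 3, like compound 1 and compound 2, gives only a limit in this assay, so neither the step from compound 2 to compound 3 nor the step from compound 1 to compound 3 can be read: the limit of > 10000 nM in this assay, at which 2 of the 3 values shown sit.

The compounds shown leave open how strongly each one inhibits, and whether changing the group on the carbonyl carbon alters that at all.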